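Chain extension at the benzylamine of the triazine series

The source may hold more compounds than are shown below. What is called first, only, known or untested is meant among the compounds shown, and "the series" means these compounds.

Compound 2 `COc1ccccc1CNc1nc(N)nc(-c2c(F)cccc2CO)n1` stands highest of the two numbers obtained so far: in a functional assay on cells for positive allosteric modulation of G-protein coupled receptor 68 (Homo sapiens), read by a luciferase reporter and cAMP accumulation, with a stated time of 30 min, at pH 6.8 and pH 8.3, in the presence of a further agent that is not named here (on this read-out higher numbers stand for higher potency (the scale is a negative logarithm) and lower numbers for lower potency), compound 2 gives 4.11, while compound 1 `Nc1nc(NCc2ccccc2)nc(-c2c(F)cccc2CO)n1` gives 3.69. For the measured compounds named here, the one measured step, a number 0.42 log units higher from compound 1 to compound 2 (beyond the scatter), is the only direct guide within this set.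

Compound 3 `Nc1nc(NCCCc2ccccc2)nc(-c2c(F)cccc2CO)n1` has not been measured. It differs from compound 2 by phenethyl in place of 2-methoxyphenyl on a saturated chain carbon bound to a nitrogen on an aromatic ring. Part of this change undoes the step from compound 1 to compound 2, as the methoxy is lost; the other part, the longer chain between the ring nitrogen and the phenyl, has no counterpart among the measured pairs, so its contribution is unknown.

Because a number 0.42 log units higher from compound 1 to compound 2 (beyond the scatter) was modest and compound 1 gives 3.69 without the methoxy, the expectation for compound 3 is a drop of similar size, a number 0.36 log units lower from compound 2 to compound 3 (beyond the scatter), landing near the level of compound 1. Compound 3 is therefore estimated at 3.75 in this assay, with a range from 3.25 to 4.3; given how low these numbers already are, a result reported only as a limit is plausible.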

Compound 3, negative logarithm of the antagonist equilibrium constant: 4.47
The estimate for compound 3 lay 0.72 log units below the measured number; measured number outside the range, above it.
By their numbers in this assay, from the lowest: compound 1; then compound 2; then compound 3.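

In this assay, phenethyl in place of phenyl on a saturated chain carbon bound to a nitrogen on an aromatic ring gives a number 0.78 log units higher from compound 1 to compound 3 (beyond the scatter) and shows that this position responds to the chain itself with no methoxy present, which the earlier pair, differing only by methoxy in place of hydrogen, could not show. Phenethyl in place of 2-methoxyphenyl gives a number 0.36 log units higher from compound 2 to compound 3 (beyond the scatter) and places compound 3 highest of the three, its steps to both others being beyond the scatter, so at this position the methoxy is not needed to reach the top number of the set. Nothing available here accounts for the rise that comes with phenethyl.

Open, going by these compounds, is whether a longer chain than phenethyl keeps raising the number or turns it down again, and whether a chain carrying an amine or a carboxylic acid is tolerated at this position. Also open, on these data alone, is whether methoxy in place of hydrogen on the aromatic ring of the phenethyl group adds a further step to the one seen with the chain, or whether the two changes fail to add up.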